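This account rests on a few compounds, and the source may have more. Where it says the series, first, only, none or still open, it means among the compounds named here.

Measured compounds:
Compound 1 `CC(C)c1ccccc1-c1cccc(COc2ccc(S(=O)(=O)CC(=O)O)cc2)c1`: 74.1 nM
Compound 2 `Cc1ccc(-c2cccc(COc3ccc(S(=O)(=O)CC(=O)O)cc3)c2)c(Cl)c1`: 36.3 nM

Both were tested in a functional assay on CHO cells for agonist activity at Free fatty acid receptor 1 (Homo sapiens), read by FLIPR and calcium flux; on this read-out lower numbers stand for an effect already at smaller amounts and higher numbers for an effect only at larger amounts of compound. Compound 2 has the lowest number of the two; its nearest neighbour is compound 1, and the step of a 2.0-fold lower number from compound 1 to compound 2 (0.31 log units; beyond the scatter) is modest but beyond the scatter. Compound 3 `Cc1noc(C)c1-c1cccc(COc2ccc(S(=O)(=O)CC(=O)O)cc2)c1` has not yet been measured. It differs from compound 2 in one place: 3,5-dimethyl-1,2-oxazol-4-yl in place of 2-chloro-4-methylphenyl on an aromatic carbon. Going by the values given here, the only measured step, a 2.0-fold lower number from compound 1 to compound 2 (0.31 log units; beyond the scatter), exchanges one six-membered aromatic ring of carbon only for another bearing different substituents and shows that such an exchange moved the number only modestly. Among the compounds with values here, no measured step replaces that six-membered ring with a five-membered aromatic ring containing hetero atoms, so the expectation rests on the observation that the two aromatic groups tried so far gave numbers of similar size. A small move toward a higher number in this assay is expected, near the edge of the scatter, a 2.8-fold higher number from compound 2 to compound 3 (0.44 log units; beyond the scatter). Compound 3 is therefore estimated at 100 nM, with a range from 30 nM to 400 nM.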

Compound 3, half-maximal effective concentration: 269 nM
Compound 3: middle estimate off by 2.7-fold (0.43 log units), on the low side, and the stated range covers the measured number.
By their numbers in this assay, from the lowest: compound 2; then compound 1; then compound 3.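

Going by these compounds alone, the earlier pair showed only that one six-membered aromatic ring of carbon could replace another on this aromatic carbon with a small change. Compound 3 changes the kind of ring, and in this assay the 3,5-dimethyl-1,2-oxazol-4-yl group gives a 7.4-fold higher number from compound 2 to compound 3 (0.87 log units; beyond the scatter) and a 3.6-fold higher number from compound 1 to compound 3 (0.56 log units; beyond the scatter). This position therefore responds more to the change to a five-membered aromatic ring with 2 hetero atoms than it did to the exchange of one carbon ring for the other, which gave a 2.0-fold lower number from compound 1 to compound 2 (0.31 log units; beyond the scatter), but ring size, ring atoms and attached groups all change together, and nothing available explains the shift.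

On these data alone, it remains open whether ring size or the hetero atoms matter more: a thiophene ring would keep the five-membered size with a single sulfur atom, whereas a pyridine ring would keep the six-membered size with a single nitrogen atom. The role of the two methyl groups is also unresolved, and a 1,2-oxazol-4-yl ring without them would test it directly.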